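Acyclic pyrimidine nucleoside analogues on cervical cells

This account rests on a few compounds, and the source may have more. Where it says the series, first, only, none or still open, it means among the compounds named here.

The series is built on one shared core carrying a three-carbon ether chain on a ring nitrogen. Compound 1 `O=c1[nH]c(=O)n(COC(CO)CO)cc1O` bears a hydroxy group on the ring; compound 2 `Cc1c(I)c(=O)[nH]c(=O)n1COC(CO)CO` carries a methyl and an iodine there instead; compound 3 `Nc1cn(COC(CO)CO)c(=O)[nH]c1=O` is the amino counterpart of compound 1.

All are tested in a functional assay on HeLa cells (Homo sapiens) for inhibition, read by MTT assay, with a stated time of 72 h; on this read-out higher numbers stand for weaker inhibition and lower numbers for stronger inhibition. Compound 1 gives no number in this assay, only a limit of > 100000 nM. Compound 1 thus sits at the limit of > 100000 nM in this assay, at which 1 of the 2 values shown sits. Compound 2 gives 73000 nM in this assay, a weak effect at the top of the tested range.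

Compound 3 differs from compound 1 by amino in place of hydroxy on an aromatic carbon. For the measured compounds named here, no measured pair of this kind exists, so the effect of the change is unknown. With only a limit for compound 1 and a weak value for compound 2, compound 3 is expected to remain weak, with the estimated step of a number no higher from compound 1 to compound 3 (the limit leaves the size open) amounting to nothing beyond the usual scatter. Compound 3 is therefore estimated at 100000 nM, within 30000 nM to 300000 nM, and a limit rather than a number is quite likely.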

Compound 3, half-maximal inhibitory concentration: > 100000 nM
Compound 3 gave a limit, no number (the forecaster's own chance of this, stated with the estimate: 60%); the middle value sits exactly at the limit.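

For the compounds shown here, compound 1 and compound 3 both give only a limit, so no step between them can be read for amino in place of hydroxy on an aromatic carbon. Most values shown sit at that limit: the limit of > 100000 nM in this assay, at which 2 of the 3 values shown sit. The compounds shown leave open whether this change alters inhibition at all.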